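A few compounds are considered here, and "the series" means these few. Any claim that something is new, unique, unknown or untested is made for them only; others in the source may bear on it.

Compound 3 `Cn1c(-c2ccc(NC(=O)CN3CCN(c4ccccc4)CC3)cc2)nc(-c2ccccc2)c1-c1ccccc1` gives 12.1% in a functional assay on MCF7 cells (Homo sapiens) for cytotoxicity, read by MTT assay, with a stated time of 24 h, tested at 0.64 ug/mL (a higher number here means a stronger effect of the compound at the concentration tested, a lower number a weaker effect), the lowest of the three numbers measured. Compound 1 `Cn1c(-c2ccc(NC(=O)CSc3nc4ccccc4o3)cc2)nc(-c2ccccc2)c1-c1ccccc1` gives 18.7%, and the step of a number 6.6 percentage points lower from compound 1 to compound 3 (within the scatter) stays within the scatter. Compound 2 `Cn1cnnc1SCC(=O)Nc1ccc(-c2nc(-c3ccccc3)c(-c3ccccc3)n2C)cc1` gives 33.1%, and the step of a number 21 percentage points lower from compound 2 to compound 3 (beyond the scatter) is beyond it, as is a number 14.4 percentage points higher from compound 1 to compound 2 (beyond the scatter).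

Compound 4 `COc1ccc(CN2CCN(CC(=O)Nc3ccc(-c4nc(-c5ccccc5)c(-c5ccccc5)n4C)cc3)CC2)cc1` differs from compound 3 by 4-methoxybenzyl in place of phenyl on an amine nitrogen in a ring. The measured steps all vary the group on the saturated chain carbon bound to the carbonyl carbon; none changes the group on the ring amine nitrogen, so none bears directly on this step. The expected step of a number 1.9 percentage points higher from compound 3 to compound 4 (within the scatter) is therefore small, not beyond the scatter. For compound 4 the estimate in this assay is 14%, with a range of 4% to 28%.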

Compound 4, a percentage reported as activity, at one concentration (the size of the read-out at that concentration, not a potency): 1%
Compound 4: middle estimate off by 13 percentage points, on the high side; measured number outside the range, below it.
By their numbers in this assay, from the lowest: compound 4; then compounds 3 and 1 (each within the scatter of the next); then compound 2.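

In this assay, the ring amine nitrogen responds to substitution: with 4-methoxybenzyl in place of phenyl, the read-out shows a number 11.1 percentage points lower from compound 3 to compound 4 (beyond the scatter). Going by these compounds alone, this is the first evidence from this position, as the earlier steps changed only the group on the saturated chain carbon bound to the carbonyl carbon. No available evidence accounts for the drop.

Open, from the compounds shown here alone, is whether the methylene link or the methoxy group carries the step; an unsubstituted benzyl or a 4-methoxyphenyl group on this nitrogen would separate the two.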